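The source may report more compounds than this note shows. Statements on the series, on what has been measured and on what is new or still open speak of the compounds shown alone.

Measured so far:
compound 1 `CCO[C@@H](C)CN1CCC[C@H](Cn2c(-c3cccnc3C)nc3cn(-c4cccc(OC)c4)nc3c2=O)C1` – 5 nM
compound 2 `COc1cccc(-n2cc3nc(-c4cccnc4C)n(C[C@H]4CCCN(CC5CCCCO5)C4)c(=O)c3n2)c1` – 120 nM
compound 3 `COc1cccc(-n2cc3nc(-c4cccnc4C)n(C[C@H]4CCCN(Cc5cnco5)C4)c(=O)c3n2)c1` – 120 nM

In an assay on HEK293 cells for displacement of a labelled ligand from growth hormone secretagogue receptor type 1 (Homo sapiens), with a stated time of 60 min (on this read-out lower numbers stand for stronger inhibition and higher numbers for weaker inhibition), compound 3 stands level with compound 2 at the digits shown, and the two together give the highest numbers of the three; compound 1 is the furthest away, as a 24-fold higher number from compound 1 to compound 3 (1.38 log units; beyond the scatter) shows. Compound 4 `CCO[C@H](C)CN1CCC[C@H](Cn2c(-c3cccnc3C)nc3cn(-c4cccc(OC)c4)nc3c2=O)C1` is the unmeasured partner: 1-ethoxyethyl in place of 1,3-oxazol-5-yl on a saturated chain carbon bound to an amine nitrogen in a ring. For the measured compounds named here, the group that enters is the one that compound 1 carries, and the step of a 24-fold higher number from compound 1 to compound 3 (1.38 log units; beyond the scatter), like a 24-fold higher number from compound 1 to compound 2 (1.38 log units; beyond the scatter), was large, while no change at the digits printed from compound 2 to compound 3 (within the scatter) was not. Reversing the large step suggests a markedly lower number in this assay. Compound 4 is therefore expected to give about 12 nM, in a range from 3 nM to 60 nM, an estimated step of a 10-fold lower number from compound 3 to compound 4 (1.00 log units; beyond the scatter).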

Compound 4, half-maximal inhibitory concentration: 40 nM
Estimate against measurement, compound 4: 3.3-fold (0.52 log units) below; the range from low to high includes it.
By their numbers in this assay, from the lowest: compound 1; then compound 4; then compounds 2 and 3 (each within the scatter of the next).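

In this assay, 1-ethoxyethyl still gives a lower number than the two other groups when its stereocentre is drawn R, with a 3.0-fold lower number from compound 3 to compound 4 (0.48 log units; beyond the scatter) and a 3.0-fold lower number from compound 2 to compound 4 (0.48 log units; beyond the scatter) but neither step is large. The earlier large steps therefore depended on the S form as well as on the group. The stereocentre alone accounts for an 8.0-fold higher number from compound 1 to compound 4 (0.90 log units; beyond the scatter) and the reason for tying the step to it is this: the fact that compounds 1 and 4 differ only in the configuration as drawn.

Still open, going by these compounds, is whether 1-methoxyethyl or 1-(dimethylamino)ethyl at this place would match compound 1. On these data alone, how the configuration would act in those groups is also open.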